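Cyclohexyl in Place of a Branched Alkene on the Alkyne

A few compounds are considered here, and "the series" means these few. Any claim that something is new, unique, unknown or untested is made for them only; others in the source may bear on it.

Three compounds share the same core, a phenylpropanoic acid carrying a triple bond, and differ only in the group at the far end of that triple bond. In a functional assay on 1321-N1 cells for agonist activity at Free fatty acid receptor 1 (Homo sapiens), read by calcium flux, with a stated time of 0.4 s (a higher number here means that more compound is needed for the effect, a lower number that less compound is needed), compound 1 `CC(C)=C(C)C#Cc1ccc(CCC(=O)O)cc1` gives 83.2 nM. In this assay compound 2 `C/C=C/C#Cc1ccc(CCC(=O)O)c(F)c1` gives 209 nM, and compound 3 `O=C(O)CCc1ccc(C#CCc2ccccc2)cc1` gives 389 nM. Compound 1 thus has the lowest number of the three; compound 2 sits beyond the usual scatter above it, and compound 3 further still. No two of these compounds differ in just one place, so none of these gaps can be tied to a single change.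

Compound 4 `O=C(O)CCc1ccc(C#CC2CCCCC2)cc1` has not yet been measured. It differs from compound 1 in one place: cyclohexyl in place of 1,2-dimethylprop-1-en-1-yl on a triple-bonded carbon. A saturated six-membered carbon ring takes over the spot that a branched, double-bonded chain of five carbons occupied. Going by the values given here, since no one-place step is known among the measured compounds, the expectation rests on the spread of the three values alone. The step of a 1.4-fold higher number from compound 1 to compound 4 (0.16 log units; within the scatter) is expected to be small, at most slightly toward a higher number. Compound 4 is therefore estimated at 120 nM, within a range from 35 nM to 400 nM.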

Compound 4, half-maximal effective concentration: 513 nM
For compound 4 the middle estimate is 4.3-fold (0.63 log units) below the measured one; the whole stated range lies below it.
By their numbers in this assay, from the lowest: compound 1; then compounds 2, 3 and 4 (each within the scatter of the next, the first and the last beyond it).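

Swapping 1,2-dimethylprop-1-en-1-yl for cyclohexyl on a triple-bonded carbon gives the first one-place comparison in this set, and in this assay it produces a 6.2-fold higher number from compound 1 to compound 4 (0.79 log units; beyond the scatter) on the shared core. The position therefore responds to a change between two all-carbon groups, neither of which has hydrogen-bond donors, hydrogen-bond acceptors or a net charge; what differs is one more carbon, a six-membered ring, and the loss of the double bond, and this single step cannot separate those three changes. No measurement shown here explains the rise in the number.

Going by these compounds, it remains open whether the ring, the lost double bond or the extra carbon accounts for the step. A cyclohexenyl group, which keeps a six-membered ring and restores a double bond, and 3-methylbutyl, an open saturated chain, placed on the same triple-bonded carbon of the core of compound 1, would help pull these changes apart.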